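Furan to thiophene on the shared core of compound 1

The source may report more compounds than this note shows. Statements on the series, on what has been measured and on what is new or still open speak of the compounds shown alone.

Compound 1 `O=c1[nH]cnc2c1c(-c1ccoc1)cn2[C@@H]1O[C@H](CO)[C@@H](O)[C@H]1O` is the weakest inhibitor of the three measured compounds; in a functional assay on K562 cells (Homo sapiens), read by MTT assay, with a stated time of 72 h (a lower number here means a stronger inhibitor, a higher number a weaker inhibitor), compound 1 gives 12500 nM. Compound 2 `COc1ncnc2c1c(-c1ccoc1)cn2[C@@H]1O[C@H](CO)[C@@H](O)[C@H]1O` gives 190 nM and compound 3 `CN(C)c1ncnc2c1c(-c1ccoc1)cn2[C@@H]1O[C@H](CO)[C@@H](O)[C@H]1O` gives 1540 nM. Going by the values given here, the only one-place step known, an 8.1-fold higher number from compound 2 to compound 3 (0.91 log units; beyond the scatter), concerns a different substitution and does not bear on the ring swap considered here. Compound 4 `O=c1[nH]cnc2c1c(-c1cccs1)cn2[C@@H]1O[C@H](CO)[C@@H](O)[C@H]1O` differs from compound 1 by thiophen-2-yl in place of furan-3-yl on an aromatic carbon. Among the compounds with values here, no measured step involves this change, so nothing speaks for a shift in either direction in this assay; the expectation is therefore a step within the scatter, no change at the digits printed from compound 1 to compound 4 (within the scatter), carrying a wide uncertainty. Compound 4 is accordingly estimated at 12500 nM, with a range from 4000 nM to 40000 nM.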

Compound 4, half-maximal inhibitory concentration: > 20000 nM
Compound 4 was reported as a limit; the forecaster's own chance of this, stated with the estimate: 15%; middle value at least 1.6-fold (0.20 log units) from the limit.
By their numbers in this assay, from the lowest: compound 2; then compound 3; then compound 1. At a limit, above all of these: compound 4.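

Read in this assay the swap gives an at least 1.6-fold higher number from compound 1 to compound 4 (0.20 log units; that floor lies within the scatter) and so shows only a floor for the step. The value of compound 4 is a limit, not a number, and the true size of the step stays unread. New here is that, at this aromatic carbon of the shared core, thiophen-2-yl in place of furan-3-yl brings no gain in potency. Open, going by these compounds, is whether the sulfur or the changed point of attachment carries the step; thiophen-3-yl or furan-2-yl here would separate the two. Also open, on these data alone, is how this swap reads alongside the methoxy group of compound 2.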